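The compounds below may be only part of what the source reports. "The series", "measured", "known", "first", "only" and "open" are said of these compounds alone.

Measured compounds:
Compound 1, `Cc1cc(-c2cccc(C#N)c2)cn2c(CSCCc3ccccc3)cnc12`, gives > 50 ug/mL in an ADME assay on HEL cells (Homo sapiens) for cytotoxicity, with a stated time of 3 days; a higher number here means that more compound is tolerated, a lower number that less compound is tolerated; this value is a limit of the assay rather than a number.
Compound 2, `c1ccc(CCSCc2cnc3ccc(-c4ccccc4)cn23)cc1`, gives 9.9 ug/mL in this assay.

Compound 1 stands at the limit (the limit of > 50 ug/mL in this assay, at which 1 of the 2 values shown sits), so its tolerated concentration is known only as a bound. For the measured compounds named here, compound 2, the other measured compound, gives a number below that bound; since no step between the two is given, nothing more is said of how they relate.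

The unmeasured compound 3, `Cc1cc(Br)cn2c(CSCCc3ccccc3)cnc12`, differs from compound 1 in one place: bromo in place of 3-cyanophenyl on an aromatic carbon. The change removes the six-membered aromatic ring with its nitrile and leaves a single bromine on the aromatic carbon of the shared core.

Going by the values given here, no measured step exists to anchor this change. Compound 1 sits at a limit, so any movement downward would show only if compound 3 falls below it. The expected step of an at least 1.6-fold lower number from compound 1 to compound 3 (0.22 log units; that floor lies within the scatter) is a modest downward one, close to the scatter. Compound 3 is therefore estimated at 30 ug/mL, with a range from 8 ug/mL to 60 ug/mL.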

Compound 3, half-maximal cytotoxic concentration: 28 ug/mL
For compound 3 the middle estimate is 1.1-fold (0.03 log units) above the measured one, and the stated range covers the measured number.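

In this assay, putting bromo in place of 3-cyanophenyl on this aromatic carbon gives an at least 1.7-fold lower number from compound 1 to compound 3 (0.25 log units; that floor lies within the scatter), so this position now has its first readable step, though only as a floor. Compound 3 also gives this position a measured number on the shared core, where the 3-cyanophenyl group had left only a bound. The value of compound 1, > 50 ug/mL, is a limit of the assay, and the full size of the step stays unknown for that reason: the limit of > 50 ug/mL in this assay, at which 1 of the 3 values shown sits.

Still open, from the compounds shown here alone, is what a plain phenyl, a methoxy group or an amine on this aromatic carbon would give on the core of compound 1, and so whether the nitrile or the aromatic ring of the departing group accounts for the step. Also open, going by these compounds, is what the methyl group on the shared core contributes, as compound 2 differs from compound 1 and compound 3 in more than one place and offers no clean comparison with either.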